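A few compounds are considered here, and "the series" means these few. Any claim that something is new, unique, unknown or untested is made for them only; others in the source may bear on it.

The measured compounds:
compound 1 `CCOC(=O)C1=Cc2ccccc2OC1(OCc1cn(CC(=O)Nc2ccc(C)cc2)nn1)C(F)(F)F`: > 150000 nM
compound 2 `CCOC(=O)C1=Cc2ccccc2OC1(OCc1cc(-c2ccc(Br)cc2)no1)C(F)(F)F`: > 150000 nM
compound 3 `O=C(O)C1=Cc2ccccc2OC1(OCc1cc(-c2ccc(F)cc2F)no1)C(F)(F)F`: > 150000 nM

In a functional assay on MCF7 cells (Homo sapiens) for inhibition, read by MTT assay, with a stated time of 24 h (a higher number here means a weaker inhibitor, a lower number a stronger inhibitor), compound 1 gives no number, only a limit of the assay, > 150000 nM. Compound 2 and compound 3 stand no differently, since (the limit of > 150000 nM in this assay, at which 3 of the 3 values shown sit). Compound 1 therefore has no defined position among the three; all that is known is that none of them reached a measurable half-maximal inhibitory concentration.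

Compound 4 `CCOC(=O)C1=Cc2ccccc2OC1(OCc1cn(-c2ccc(F)c(Cl)c2)nn1)C(F)(F)F` differs from compound 1 in one place: 3-chloro-4-fluorophenyl in place of ((4-methylphenyl)carbamoyl)methyl on an aromatic nitrogen. For the measured compounds named here, with every value shown sitting at a limit, there is no measured step to lean on, and compound 4 is expected to stay near the same limit, a step that the limit leaves unreadable from compound 1 to compound 4 that is not expected to exceed the scatter. The estimate for compound 4 in this assay is 200000 nM, within 60000 nM to 600000 nM.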

Compound 4, half-maximal inhibitory concentration: 25300 nM
For compound 4 the middle estimate is 7.9-fold (0.90 log units) above the measured one, and the stated range ends above it.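

In this assay, the aromatic nitrogen of the five-membered ring proves to be a position where a change can bring the read-out off the limit: 3-chloro-4-fluorophenyl in place of ((4-methylphenyl)carbamoyl)methyl gives an at least 5.9-fold lower number from compound 1 to compound 4 (0.77 log units; beyond the scatter). This size is only a lower bound, because compound 1 gives a limit and no number: the limit of > 150000 nM in this assay, at which 3 of the 4 values shown sit.

Going by these compounds, whether the chlorine, the fluorine or the directly attached aromatic ring accounts for the step remains open, as does whether a plain phenyl would give the same result. Also open, on these data alone, is how a carboxylic acid in place of the ethyl ester would behave alongside this group.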